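A few compounds are considered here, and "the series" means these few. Any claim that something is new, unique, unknown or untested is made for them only; others in the source may bear on it.

Of the compounds shown here, three of one series share a core and have been tested in an ADME assay on microsomes from liver (Mus musculus), read by LC-MS, using NADPH, with a stated time of 30 min, tested at 1 uM; on this read-out higher numbers stand for a more stable compound and lower numbers for a less stable compound. Compound 1 `C[C@H](Nc1nc(N)nc(N)c1C#N)c1cc2ccc(F)cn2c(=O)c1-c1ccc(F)cc1` gives 84% in this assay. Compound 2 `C[C@H](Nc1nc(N)nc(N)c1C#N)c1cc(=O)n2cc(F)ccc2c1-c1cc(F)cc(F)c1` gives 90% in this assay. Compound 3 `C[C@H](Nc1nc(N)nc(N)c1C#N)c1c(-c2ccccc2)c(=O)n2cc(F)ccc2c1C1CC1` gives 87% in this assay. On these numbers compound 3 sits within the usual scatter of both compound 1 and compound 2, so the three measured compounds cannot be told apart in this assay; all three are left largely intact over the stated time.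

Compound 4 `COc1ccc(-c2c([C@H](C)Nc3nc(N)nc(N)c3C#N)c(-c3ccccc3)c(=O)n3cc(F)ccc23)cc1` has not yet been measured in this assay. It differs from compound 3 in one place: 4-methoxyphenyl in place of cyclopropyl on an aromatic carbon. Going by the values given here, no step between measured compounds bears on such a change, so there is no direct reference for its size. Since compound 1, compound 2 and compound 3 all stand high in this assay, the expectation for compound 4 is that the change a number 9 percentage points lower from compound 3 to compound 4 (within the scatter) stays within the scatter, or at most brings a small decrease. On that basis compound 4 is estimated to give 78% in this assay, with a likely range from 60% to 92%.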

Compound 4, percent of the compound remaining: 82%
The estimate for compound 4 lay 4 percentage points below the measured number, within the range that was stated.
By their numbers in this assay, from the lowest: compounds 4, 1, 3 and 2 (each within the scatter of the next).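

Going by these compounds alone, this is the first step that can be read at this position: on this aromatic carbon, ortho to a fused ring and two atoms from the ring nitrogen, cyclopropyl with 3 heavy atoms gives way to 4-methoxyphenyl with 8 heavy atoms and a hydrogen-bond acceptor, and this assay shows a number 5 percentage points lower from compound 3 to compound 4 (within the scatter). The position therefore carries a three-membered non-aromatic ring or a much larger six-membered aromatic ring without a difference that can be told from the scatter, and compound 4, at 82%, remains largely intact over the stated time. No measurement accompanying this result speaks to what lies behind it.

With only these two groups at this place, the compounds shown leave open whether a group of another kind, such as a primary amine or a carboxylic acid, would read the same in this assay. They also leave open what the methoxy group contributes on its own, since a plain phenyl or a 4-hydroxyphenyl on this carbon would be needed to separate it from the aromatic ring that carries it.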